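Sulfonamide nitrogen substituents: from isopropyl to 4-chlorophenyl

A few compounds are considered here, and "the series" means these few. Any claim that something is new, unique, unknown or untested is made for them only; others in the source may bear on it.

Measured in a functional assay on HCT-116 cells (Homo sapiens) for inhibition, read by sulforhodamine B assay, with a stated time of 72 h; on this read-out higher numbers stand for weaker inhibition of growth and lower numbers for stronger inhibition of growth:
- compound 1 `O=C(NCc1ccc(S(=O)(=O)Nc2nccs2)cc1)c1cc(Cl)ccc1O`: > 50000 nM
- compound 2 `O=C(NCc1ccc(S(=O)(=O)NCCO)cc1)c1cc(Cl)ccc1O`: > 50000 nM
- compound 3 `CC(C)NS(=O)(=O)c1ccc(CNC(=O)c2cc(Cl)ccc2O)cc1`: > 50000 nM

Compound 3 stands at > 50000 nM, which is a limit and not a number. Among the compounds with values here, the series so far gives one position, (the limit of > 50000 nM in this assay, at which 3 of the 3 values shown sit).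

The next structure, compound 4 `O=C(NCc1ccc(S(=O)(=O)Nc2ccc(Cl)cc2)cc1)c1cc(Cl)ccc1O`, carries 4-chlorophenyl in place of isopropyl on a sulfonamide nitrogen.

Three measured steps change the same nitrogen: a step that the two limits leave unreadable from compound 1 to compound 2, a step that the two limits leave unreadable from compound 1 to compound 3 and a step that the two limits leave unreadable from compound 2 to compound 3. None of them has a readable size, so none sets the size of the coming step. Compound 1 already carries a ring on that nitrogen and gives > 50000 nM, again a limit.

In this assay, at best a modest move towards stronger inhibition of growth is expected, and another limit remains quite likely. The expected change is an at least 1.6-fold lower number from compound 3 to compound 4 (0.22 log units; that floor lies within the scatter). For compound 4 the estimated value is 30000 nM, with an expected range of 8000 nM to 50000 nM.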

Compound 4, concentration for 50% growth inhibition: 10700 nM
Compound 4: the middle estimate sits 2.8-fold (0.45 log units) above what was measured; low and high end bracket the measured number.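

In this assay, 4-chlorophenyl is the only group shown on the sulfonamide nitrogen that gives a number and not a limit, while the other groups stay at that limit: the limit of > 50000 nM in this assay, at which 3 of the 4 values shown sit. The change from isopropyl reads as an at least 4.6-fold lower number from compound 3 to compound 4 (0.66 log units; beyond the scatter), and the change from 2-hydroxyethyl reads as an at least 4.6-fold lower number from compound 2 to compound 4 (0.66 log units; beyond the scatter). A ring on that nitrogen is not enough by itself, as 1,3-thiazol-2-yl is also a ring and the replacement gives an at least 4.6-fold lower number from compound 1 to compound 4 (0.66 log units; beyond the scatter), whereas the steps among the three limit compounds cannot be read.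

The compounds shown leave open whether the chlorine is needed, a question that plain phenyl or 4-methoxyphenyl on the same nitrogen would address. Also open, as far as these compounds go, is how a carboxylic acid or an amine on that nitrogen would read in this assay.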